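Thiophen-2-yl in place of 4-chlorophenyl on compound 3

A few compounds are considered here, and "the series" means these few. Any claim that something is new, unique, unknown or untested is made for them only; others in the source may bear on it.

Measured so far:
- compound 1 `Cn1cccc1CNC(=S)SCCC#N` gives 227000 nM
- compound 2 `S=C(NCc1cccnc1)SCCc1nnn[nH]1` gives 57700 nM
- compound 3 `S=C(NCc1cccnc1)SCCc1nnc(-c2ccc(Cl)cc2)o1` gives 1260 nM

In a functional assay on Bel-7402 cells (Homo sapiens) for cytotoxicity, read by resazurin assay, with a stated time of 72 h (on this read-out higher numbers stand for weaker inhibition and lower numbers for stronger inhibition), compound 3 gives 1260 nM, the lowest of the three numbers. Its gaps to compound 2 and compound 1 both lie beyond the scatter. The next compound is compound 4 `S=C(NCc1cccnc1)SCCc1nnc(-c2cccs2)o1`, which differs from compound 3 by thiophen-2-yl in place of 4-chlorophenyl on an aromatic carbon, with thiophen-2-yl in place of 4-chlorophenyl on an aromatic carbon. Among the compounds with values here, no measured pair isolates a change at this place, so any expectation here is weakly supported. A modest move toward weaker inhibition in this assay is expected. The estimated step is a 2.4-fold higher number from compound 3 to compound 4 (0.38 log units; beyond the scatter), a rough figure. For compound 4 the estimate is 3000 nM, with an expected range of 1000 nM to 10000 nM.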

Compound 4, half-maximal inhibitory concentration: 1340 nM
Estimate against measurement, compound 4: 2.2-fold (0.35 log units) above, and the stated range covers the measured number.
By their numbers in this assay, from the lowest: compounds 3 and 4 (each within the scatter of the next); then compound 2; then compound 1.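

In this assay, within the data shown here, thiophen-2-yl in place of 4-chlorophenyl gives (a 1.1-fold higher number from compound 3 to compound 4 (0.03 log units; within the scatter)), the first single-place comparison. This aromatic carbon therefore accepts a five-membered sulfur-containing ring as readily as a chlorinated six-membered ring, and the low number seen with compound 3 does not depend on the 4-chlorophenyl group. Nothing available accounts for this equivalence.

Open, from the compounds shown here alone, is whether an aryl group is needed here at all, or whether a simple methyl, an aminomethyl or a carboxylic acid at this place would keep the number.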